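Swapping a Sulfopropyl Chain for an Ester Group

The source may hold more compounds than are shown below. What is called first, only, known or untested is meant among the compounds shown, and "the series" means these compounds.

Among the measured compounds shown here, in a functional assay for inhibition (a lower number here means a stronger inhibitor, a higher number a weaker inhibitor), compound 1 (`CC(C)(C)c1cc(-c2cc(=O)c3ccc(OCC(=O)O)cc3o2)cc(C(C)(C)C)c1O`) gives 3000 nM; 100 nM (2 entries) and compound 2 (`CC(C)(C)c1cc(-c2cc(=O)c3ccc(OCCCS(=O)(=O)O)cc3o2)cc(C(C)(C)C)c1O`) gives 500 nM as its only single number, a value inside the spread of compound 1 and joined by one further entry without a number. Compound 3 (`CCOC(=O)C(C)(C)Oc1ccc2c(=O)cc(-c3cc(C(C)(C)C)c(O)c(C(C)(C)C)c3)oc2c1`) is still unmeasured. It carries 1-(ethoxycarbonyl)-1-methylethyl in place of 3-sulfopropyl on an oxygen on an aromatic ring. For the measured compounds named here, no measured step shows what this swap does, so only a modest weakening is expected (a 3.0-fold higher number from compound 2 to compound 3 (0.48 log units; beyond the scatter)). The range must stay wide because the several entries of compound 1 in this assay, 3000 nM; 100 nM (2 entries) lie far apart. The expected value for compound 3 is 1500 nM (estimated range 200 nM to 8000 nM).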

Compound 3, half-maximal inhibitory concentration: 3000 nM
Compound 3: middle estimate off by 2.0-fold (0.30 log units), on the low side; low and high end bracket the measured number.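

Among the compounds shown here, this is the first direct reading of this swap on the oxygen on an aromatic ring: in this assay, 1-(ethoxycarbonyl)-1-methylethyl in place of 3-sulfopropyl gives a 6.0-fold higher number from compound 2 to compound 3 (0.78 log units; beyond the scatter). The group on this oxygen therefore matters, and the sulfonic acid end is not needed for measurable inhibition, since compound 3 still gives 3000 nM. The size of the step remains uncertain because the values for the shared core vary widely: the several entries of compound 1 in this assay, 3000 nM; 100 nM (2 entries).

The swap changes the chain and its end group together, and the compounds shown do not separate the two. From the compounds shown here alone, what an amine at the end of a longer chain would do on this oxygen remains open.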